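Swapping isopropyl for trifluoromethyl on a permeability core

The source may report more compounds than this note shows. Statements on the series, on what has been measured and on what is new or still open speak of the compounds shown alone.

Measured compounds:
- compound 1 `CC(C)c1nnc2n1C[C@H](C)N(C(=O)c1cccc(C(F)(F)c3n[nH]c(=O)c4ccccc34)c1)C2`: 2 10^-6 cm/s
- compound 2 `O=C(c1cccc(C(F)(F)c2n[nH]c(=O)c3c2CCCC3)c1)N1CCn2c(nnc2C(F)(F)F)C1`: 1.3 10^-6 cm/s
- compound 3 `C[C@@H]1Cn2c(nnc2C(F)(F)F)CN1C(=O)c1cccc(Cc2n[nH]c(=O)c3ccccc23)c1`: 1.5 10^-6 cm/s

Three compounds sharing a common core were tested in an ADME assay on Caco-2 cells (Homo sapiens) for permeability, read by LC-MS, with a stated time of 2 h, at pH 7.4, tested at 10 uM; on this read-out higher numbers stand for higher permeability and lower numbers for lower permeability. Compound 1 gives 2 10^-6 cm/s, compound 3 gives 1.5 10^-6 cm/s and compound 2 gives 1.3 10^-6 cm/s. Compound 1 sits at the top of these three numbers, but its gaps to compound 3 and to compound 2 both fall within the usual scatter of this assay, so the three compounds cannot be told apart on the numbers shown; all of them sit in the low range of permeability.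

Compound 4 `C[C@H]1Cn2c(nnc2C(F)(F)F)CN1C(=O)c1cccc(C(F)(F)c2n[nH]c(=O)c3ccccc23)c1` has not yet been measured. It differs from compound 1 in one place: trifluoromethyl in place of isopropyl on an aromatic carbon. Compound 3 and compound 2 both carry a trifluoromethyl group at the same position and both give numbers within the scatter of compound 1, so nothing in the measured set points to a large effect of this change. Compound 4 is therefore expected to give about 1.6 10^-6 cm/s, with a range from 0.8 10^-6 cm/s to 3.2 10^-6 cm/s. This estimate means a step of a 1.3-fold lower number from compound 1 to compound 4 (0.10 log units; within the scatter), which is expected to stay within the scatter rather than mark a real change in permeability.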

Compound 4, apparent permeability: 6.7 10^-6 cm/s
Beside the measured number, compound 4's estimate is 4.2-fold (0.62 log units) below it; the measured number lies above the stated range.
By their numbers in this assay, from the lowest: compounds 2, 3 and 1 (each within the scatter of the next); then compound 4.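

In this assay, trifluoromethyl in place of isopropyl on an aromatic carbon of the five-membered aromatic ring gives a 3.4-fold higher number from compound 1 to compound 4 (0.53 log units; beyond the scatter), a modest step and the first one that can be read at this position. Among these compounds, compound 2 and compound 3 also carry trifluoromethyl there, but each differs from compound 1 in more than one place, and their numbers could not show what this change does on its own; this pair shows that the number can move when only this group is exchanged, with 3 heavy atoms leaving, 4 entering, and the rest of compound 1 unchanged. Nothing available here explains why the number rises with this exchange.

Going by these compounds, with only isopropyl and trifluoromethyl compared directly at this position, it remains open how other groups there would read, such as a methyl, a cyclopropyl ring, a methoxy or an amine. On these data alone, it also remains open whether the same exchange would give a similar step with the other parts of compound 2 or compound 3 in place.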